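Amine substitution on a fused bicyclic core: methyl removal

The compounds below may be only part of what the source reports. "The series", "measured", "known", "first", "only" and "open" are said of these compounds alone.

Compound 1 `CCCCCCNc1[nH]ccc2ncnc1-2` — in a functional assay on EL4 cells (Mus musculus) for inhibition, tested at 100 uM (a higher number here means more inhibition at the concentration tested (going by the name of the read-out), a lower number less inhibition), compound 1 gives 100%
Compound 2 `CN(C)c1[nH]ccc2ncnc1-2` — in this assay compound 2 gives 25%

Two compounds of the series have been run so far, and they differ only in the group on the exocyclic nitrogen of the shared core. Compound 2 stands lowest of the two numbers; its nearest neighbour is compound 1, whose number is higher by a gap that is well beyond the usual scatter of this kind of measurement.

Compound 3 `CNc1[nH]ccc2ncnc1-2` is the next member to be measured in this assay. It differs from compound 2 by hydrogen in place of methyl on a nitrogen on an aromatic ring. Going by the values given here, the change is small in atom count, and no step between measured compounds speaks directly to it; the only comparison available, compound 1 against compound 2, changes both the chain and the hydrogen on that nitrogen at once.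

Compound 3 is expected to land between the two measured neighbours, with a step of a number 20 percentage points higher from compound 2 to compound 3 (beyond the scatter) that is estimated to exceed the scatter in the upward direction. The estimate for compound 3 in this assay is 45%, with a range from 15% to 80%.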

Compound 3, a percentage reported as inhibition, at one concentration (the size of the read-out at that concentration, not a potency): < 5%
Compound 3: a limit, no number (the forecaster's own chance of this, stated with the estimate: 0%); middle value at least 40 percentage points away from the limit.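

In this assay compound 3 gives < 5%, which is a limit of the assay and not a number: the limit of < 5% in this assay, at which 1 of the 3 values shown sits. Dimethylamino to methylamino is the first single change at this nitrogen that can be read, and hydrogen in place of methyl gives a number at least 20 percentage points lower from compound 2 to compound 3 (beyond the scatter), so the second methyl counts in this assay and the loss of one small group is enough to take the read-out down to the limit. Hydrogen in place of pentyl, on the saturated chain carbon bound to the nitrogen on the aromatic ring, gives a number at least 95 percentage points lower from compound 1 to compound 3 (beyond the scatter), which shows that, with one hydrogen kept on this nitrogen, the length of the chain carries a large part of the inhibition at the concentration tested.

The compounds shown leave open how the read-out builds up as the chain grows from methyl to the longer chain of compound 1, which an ethyl, propyl or butyl group on this nitrogen would address. They also leave open whether the dimethylamino result extends to a second longer chain on the same nitrogen, such as a diethylamino group, or to a cyclic amine such as piperidine.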